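Working notes: phenol to bromopropyl ether step

The source may report more compounds than this note shows. Statements on the series, on what has been measured and on what is new or still open speak of the compounds shown alone.

Measured in a functional assay for antagonist activity at Adrenergic receptor alpha-1 (Rattus norvegicus); a higher number here means weaker binding, a lower number tighter binding:
compound 1 `Cc1ccccc1N1CCN(CCCOc2ccc3c(=O)cc(-c4ccc(Cl)cc4)oc3c2)CC1` — 16.9 nM
compound 2 `Cc1ccccc1N1CCN(CCCCOc2ccc3c(=O)cc(-c4ccc(Cl)cc4)oc3c2)CC1` — 33.8 nM
compound 3 `O=c1cc(-c2ccc(Cl)cc2)oc2cc(O)ccc12` — 143 nM

Compound 3 gives the highest number of the three in this assay; compound 2 lies closer to it, compound 1 furthest, and both gaps lie beyond the scatter. Compound 4 `O=c1cc(-c2ccc(Cl)cc2)oc2cc(OCCCBr)ccc12` is not yet measured. It differs from compound 3 by 3-bromopropyl in place of hydrogen on an oxygen on an aromatic ring, in words: 3-bromopropyl in place of hydrogen on an oxygen on an aromatic ring. Within the data shown here, no pair of measured compounds shows this change alone; compounds 1 and 2 carry the arylpiperazine as well, so their values cannot be read as a guide to it. The step from compound 3 to compound 4 is expected to be small and toward a higher number, a 2.1-fold higher number from compound 3 to compound 4 (0.32 log units; beyond the scatter). Compound 4 is estimated at 300 nM, within 80 nM to 2000 nM.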

Compound 4, dissociation constant: 679 nM
Estimate against measurement, compound 4: 2.3-fold (0.35 log units) below; the measured number falls inside the stated range.
By their numbers in this assay, from the lowest: compounds 1 and 2 (each within the scatter of the next); then compound 3; then compound 4.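

In this assay, 3-bromopropyl in place of hydrogen on the oxygen gives a 4.7-fold higher number from compound 3 to compound 4 (0.68 log units; beyond the scatter), so alkylating this oxygen does not by itself lower the number. The 3-bromopropyl chain alone therefore does not account for compound 1 at 16.9 nM, which carries the arylpiperazine on its chain where compound 4 carries bromine. Nothing measured here bears on why the number rises.

On these data alone, whether the rise belongs to the chain or to its terminal bromine remains open. A plain propyl ether or a chain ending in a dimethylamino group would separate the two.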